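The compounds below may be only part of what the source reports. "The series", "measured", "known", "first", "only" and "open" are said of these compounds alone.

Measured so far in a functional assay on Raji cells (Homo sapiens) for cytotoxicity, read by CCK-8 assay, with a stated time of 24 h; a lower number here means a stronger inhibitor, a higher number a weaker inhibitor:
Compound 1 `C=CC(=O)N1C(=O)CC(c2ccc(C(F)(F)F)cc2)Sc2ccccc21` gives 47600 nM
Compound 2 `C=CC(=O)N1C(=O)CC(c2cccc(Cl)c2)Sc2ccccc21` gives 47100 nM
Compound 3 `C=CC(=O)N1C(=O)CC(c2ccc(-c3ccccc3)cc2)Sc2ccccc21` gives 56300 nM

Compound 3 stands within the scatter of both compound 1 and compound 2, so the three values form a single group with no order among them. The next compound to read is compound 4 `C=CC(=O)N1C(=O)CC(c2ccc(C#N)cc2)Sc2ccccc21`, which carries cyano in place of phenyl on an aromatic carbon, para to a large group (cyano in place of phenyl on an aromatic carbon). Among the measured compounds shown here, one measured step bears on this change: a 1.2-fold higher number from compound 1 to compound 3 (0.07 log units; within the scatter), with phenyl in place of trifluoromethyl on an aromatic carbon. That step stays within the scatter. For the measured compounds named here, no measured step brings in cyano, so the read-across is indirect and rests on three compounds only. Given the size of that single step, no step beyond the scatter is expected in this assay, and no direction is favoured. The expected change is a 1.1-fold lower number from compound 3 to compound 4 (0.05 log units; within the scatter), which is an estimate and not a trend. For compound 4 the estimated value is 50000 nM, with an expected range from 30000 nM to 80000 nM.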

Compound 4, half-maximal inhibitory concentration: 84500 nM
The estimate for compound 4 lay 1.7-fold (0.23 log units) below the measured number, outside the stated range (above it).
By their numbers in this assay, from the lowest: compounds 2, 1, 3 and 4 (each within the scatter of the next).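

In this assay cyano in place of phenyl on an aromatic carbon, para to a large group, gives a 1.5-fold higher number from compound 3 to compound 4 (0.18 log units; within the scatter) and cyano in place of trifluoromethyl on that carbon gives a 1.8-fold higher number from compound 1 to compound 4 (0.25 log units; within the scatter) while 4-cyanophenyl in place of 3-chlorophenyl on a saturated ring carbon gives a 1.8-fold higher number from compound 2 to compound 4 (0.25 log units; within the scatter) as the remaining step. The earlier compounds had shown only an exchange of phenyl and trifluoromethyl here, whereas these steps add a nitrile, with its triple bond and hydrogen-bond acceptor, and the loss of a six-membered aromatic ring, and still none of them leaves the scatter, so the four compounds remain one group with no order that can be relied on. Nothing at hand accounts for these numbers.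

Going by these compounds, whether an amine or a carboxylic acid on the same aromatic carbon would give a step beyond the scatter remains open. Also open, on these data alone, is whether any change to the shared core, rather than to this aryl group, would move the numbers in this assay at all.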